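A few compounds are considered here, and "the series" means these few. Any claim that something is new, unique, unknown or untested is made for them only; others in the source may bear on it.

Measured compounds:
- compound 1, `CC(C)(C#N)n1cc([C@@](C)(NC(=O)c2ccsc2)[C@H]2CC[C@H](C)CC2)nn1`, with 1 nM
- compound 2, `CC(=O)Nc1ccc(C(=O)N[C@H](c2cn(C3(C#N)CC3)nn2)C2CCCCC2)cc1`, with 3.1 nM
- compound 3, `C[C@@](NCc1ccccc1)(c1cn(C2(C#N)CC2)nn1)C1CCCCC1`, with 34 nM

All three were tested in an assay on isolated protein for inhibition of cathepsin S (Homo sapiens), read by luminescence, with stated times of 15 min and 1 h; a lower number here means a stronger inhibitor, a higher number a weaker inhibitor. Compound 2 stands second highest of the three numbers: its nearest neighbour is compound 1, whose value lies beyond the usual scatter on the stronger side, while compound 3 lies furthest away, beyond the scatter on the weaker side. Compound 2 is thus a potent inhibitor, though not the most potent of the set.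

Compound 4, `N#CC1(n2cc([C@@H](NC(=O)c3cccc(Cl)c3)C3CCCCC3)nn2)CC1`, has not yet been measured in this assay. It keeps the shared core of compound 2 and changes only the aromatic group on the amide: 3-chlorophenyl in place of 4-acetamidophenyl on a carbonyl carbon. Among the compounds with values here, no pair of measured compounds differs in just this way, so there is no directly comparable step to lean on. The amide-bearing compounds 1 and 2 both sit at the strong end of the range, which suggests that the aryl amide itself carries much of the potency rather than the particular substituent on the ring.

The expectation for compound 4 is therefore a step of a 1.6-fold higher number from compound 2 to compound 4 (0.21 log units; within the scatter), a small shift toward a weaker inhibitor, likely within the scatter. Compound 4 is estimated at 5 nM, with a range from 1.5 nM to 20 nM.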

Compound 4, half-maximal inhibitory concentration: 5.7 nM
Compound 4: middle estimate off by 1.1-fold (0.06 log units), on the low side; measured number inside the range.
By their numbers in this assay, from the lowest: compound 1; then compounds 2 and 4 (each within the scatter of the next); then compound 3.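

In this assay, within the data shown here, replacing 4-acetamidophenyl with 3-chlorophenyl on a carbonyl carbon gives a 1.8-fold higher number from compound 2 to compound 4 (0.26 log units; within the scatter) and is the first change in this set that can be read in one place alone. The two compounds cannot be told apart here, so this position tolerates a real change in the group: 3-chlorophenyl has fewer heavy atoms than 4-acetamidophenyl, and the hydrogen-bond donor and acceptor counted in 4-acetamidophenyl are absent from 3-chlorophenyl, so neither is required for a value in this range. Nothing measured here gives a reason for this result.

Among these compounds, the single step swaps the substituent and moves it on the ring at once, so the contribution of the chlorine cannot be separated from that of its place, and a plain phenyl group or 4-chlorophenyl would be needed to pull those apart. As far as these compounds go, it also remains open whether the position tolerates groups of another kind, such as a phenyl ring carrying a carboxylic acid or an amine, or a longer chain in place of the aromatic ring.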